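This account rests on a few compounds, and the source may have more. Where it says the series, first, only, none or still open, it means among the compounds named here.

Among the compounds with values here, compound 1 `COc1cccc(C)c1NC(=O)CN1CCC(c2cccc[n+]2[O-])CC1` gives 56% in a functional assay on HEK293 cells for agonist activity at D(4) dopamine receptor (Homo sapiens), read by FLIPR (on this read-out lower numbers stand for smaller maximal responses and higher numbers for larger maximal responses), the second highest of the three numbers so far. Compound 2 `COc1cccc(C(=O)NCN2CCC(c3cccc[n+]3[O-])CC2)c1C` gives 51%, within the scatter of compound 1. Within the data shown here, compound 3 `COc1cccc(C)c1NC(=O)CN1CCC(c2ccccn2)CC1` gives 69%; the change a number 13 percentage points higher from compound 1 to compound 3 (beyond the scatter) is the only step between measured compounds, and it sits on a saturated ring carbon, not on the six-membered aromatic ring of carbon only. Compound 4 `Cc1cccc(C)c1NC(=O)CN1CCC(c2cccc[n+]2[O-])CC1` differs from compound 1 by methyl in place of methoxy on an aromatic carbon. Among the measured compounds shown here, no measured step bears on this exchange; the shared core is otherwise unchanged. For compound 4 the expectation is therefore a step of a number 1 percentage points lower from compound 1 to compound 4 (within the scatter), nothing beyond the scatter. Compound 4 is expected to give about 55% in this assay, with a range from 42% to 68%.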

Compound 4, largest response reached (reported as efficacy), in percent of the reference or control that the assay uses: 68%
The estimate for compound 4 lay 13 percentage points below the measured number; measured number inside the range.
By their numbers in this assay, from the lowest: compounds 2 and 1 (each within the scatter of the next); then compounds 4 and 3 (each within the scatter of the next).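

In this assay, within the data shown here, methyl in place of methoxy gives a number 12 percentage points higher from compound 1 to compound 4 (beyond the scatter) and is the first measured change on the six-membered aromatic ring of carbon only. The response at this position, ortho to a large group, therefore changes with the substituent, and in this pair methoxy is not needed for the response. Nothing available explains the step. As far as these compounds go, whether the same exchange gives a similar step on the core of compound 3 stays open. From the compounds shown here alone, the outcome with a chlorine atom, an ethyl group or a hydroxyl group at this place also stays open.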